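Replacing the 3,4-dichlorophenyl group of compound 2

The source may report more compounds than this note shows. Statements on the series, on what has been measured and on what is new or still open speak of the compounds shown alone.

Measured so far in a functional assay on HT-29 cells (Homo sapiens) for antiproliferative activity, read by MTT assay, with a stated time of 72 h; a lower number here means a stronger inhibitor, a higher number a weaker inhibitor:
- Compound 1 `Nc1nc(N)c2cc(CSC(=S)N3CCN(c4ccc(Cl)cc4)CC3)ccc2n1` gives 7480 nM
- Compound 2 `Nc1nc(N)c2cc(CSC(=S)N3CCN(c4ccc(Cl)c(Cl)c4)CC3)ccc2n1` gives 3480 nM

Of these two numbers, the lower belongs to compound 2 (3480 nM), which makes it the stronger inhibitor of the pair. The next structure is compound 3 `Nc1nc(N)c2cc(CSC(=S)N3CCN(c4ccccc4[N+](=O)[O-])CC3)ccc2n1` which keeps the shared core and carries 2-nitrophenyl in place of 3,4-dichlorophenyl on an amine nitrogen in a ring. Compound 3 has no chloro left. Within the data shown here, the only measured step that bears on this, chloro in place of hydrogen on an aromatic carbon, was modest (a 2.1-fold lower number from compound 1 to compound 2 (0.33 log units; beyond the scatter)) and leads to the expectation of a step of similar size toward a higher number in this assay. Among the measured compounds shown here, no measured compound carries 2-nitrophenyl, and the expectation therefore stays loose. The expected step is a 2.2-fold higher number from compound 2 to compound 3 (0.33 log units; beyond the scatter) and it could turn out smaller or larger. The estimate for compound 3 is 7500 nM (expected range 2500 nM to 22000 nM).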

Compound 3, half-maximal inhibitory concentration: 4310 nM
For compound 3 the middle estimate is 1.7-fold (0.24 log units) above the measured one, within the range that was stated.
By their numbers in this assay, from the lowest: compounds 2, 3 and 1 (each within the scatter of the next, the first and the last beyond it).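

Compounds 1 and 2 varied only in their chloro substitution, whereas compound 3 shows that, in this assay, an aryl group with no chloro at all can stand on this ring nitrogen and still give a number that cannot be told apart from those of the chlorinated compounds: the change gives a 1.2-fold higher number from compound 2 to compound 3 (0.09 log units; within the scatter), and the comparison with the monochloro compound gives a 1.7-fold lower number from compound 1 to compound 3 (0.24 log units; within the scatter). Although compounds 1 and 2 differ by slightly more than the scatter, compound 3 lies within the scatter of each, so it cannot be ranked against either, even though the exchange brings in a nitro group and moves from 0 to 2 hydrogen-bond acceptors on this group. No measurement shown explains why such different aryl groups give such similar numbers.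

The compounds shown leave open whether an aromatic ring is required here at all, since all three carry a substituted phenyl group. A plain phenyl ring, a cyclohexyl ring or a phenyl ring bearing a carboxylic acid or an amine would test how much further this position can be changed.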